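Compound 1 to compound 3: a 4-nitrobenzyl swap

A few compounds are considered here, and "the series" means these few. Any claim that something is new, unique, unknown or untested is made for them only; others in the source may bear on it.

In a functional assay on A549 cells (Homo sapiens) for antiproliferative activity, read by MTT assay (a lower number here means a stronger inhibitor, a higher number a weaker inhibitor), compound 1 (`COc1ccc(-n2cc(COc3ccc(/C=C/C(=O)c4ccc5c(c4O)CCC(C)(C)O5)cc3)nn2)c([N+](=O)[O-])c1`) gives "not active" (no number reported), so it has no number to serve as a starting point. Compound 2 (`CC1(C)CCc2cc(C(=O)/C=C/c3ccc(OCc4cn(Cc5ccc([N+](=O)[O-])cc5)nn4)cc3)c(O)cc2O1`), which also carries 4-nitrobenzyl, gives 35800 nM. Compound 3 (`CC1(C)CCc2c(ccc(C(=O)/C=C/c3ccc(OCc4cn(Cc5ccc([N+](=O)[O-])cc5)nn4)cc3)c2O)O1`) has 4-nitrobenzyl in place of 4-methoxy-2-nitrophenyl on an aromatic nitrogen. Among the compounds with values here, no measured step shows what this change does, so its size in this assay cannot be stated. The expected direction is from no activity to a measurable but weak value, resting only on compound 2 at 35800 nM. The estimated value for compound 3 is 30000 nM, within a range of 10000 nM to 80000 nM.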

Compound 3, half-maximal inhibitory concentration: 69900 nM
The estimate for compound 3 lay 2.3-fold (0.37 log units) below the measured number, and the stated range covers the measured number.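

In this assay, within the data shown here, compound 1 gives "not active" (no number reported), and no step to compound 3 can be read. The compounds shown leave open how large the effect of the 4-nitrobenzyl swap is. No measurement shown bears on a cause.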